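A few compounds are considered here, and "the series" means these few. Any claim that something is new, unique, unknown or untested is made for them only; others in the source may bear on it.

Measured compounds:
compound 1: `Nc1cc(N)c2nc(-c3ccccc3)c(Oc3ccc(Cl)c(Cl)c3)nc2c1` gives 31600 nM in a functional assay on U-251 cells (Homo sapiens) for inhibition, read by sulforhodamine B assay, with a stated time of 48 h; a lower number here means a stronger inhibitor of growth, a higher number a weaker inhibitor of growth.
compound 2: `CCOC(=O)[C@H](CCC(=O)O)NC(=O)c1ccc(CNc2nc3cc(N)cc(N)c3nc2-c2ccccc2)cc1` gives < 100000 nM in this assay. This value is a limit, not a number.

Among the compounds with values here, compound 1 thus holds the only actual number in this assay. The other value shown sits at a limit (the limit of < 100000 nM in this assay, at which 1 of the 2 values shown sits). Compound 1 can therefore not be ordered against compound 2 on these data.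

Compound 3, `Nc1cc(N)c2nc(-c3ccccc3)c(Oc3ccc(F)cc3)nc2c1`, differs from compound 1 in one place: 4-fluorophenyl in place of 3,4-dichlorophenyl on an oxygen on an aromatic ring. Within the data shown here, no measured pair traces this change, so the expectation rests on compound 1 alone and on the fact that the shared core is kept. A modest weakening of growth inhibition is expected, of a size that may reach just beyond the scatter, though a result within the scatter of compound 1 would not surprise. The expected step is a 1.7-fold higher number from compound 1 to compound 3 (0.24 log units; within the scatter). For compound 3 the estimate in this assay is 55000 nM, with a range from 18000 nM to 150000 nM.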

Compound 3, concentration for total growth inhibition: 79400 nM
Beside the measured number, compound 3's estimate is 1.4-fold (0.16 log units) below it, within the range that was stated.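

Within the data shown here, the first measured step at this position, in this assay, is a 2.5-fold higher number from compound 1 to compound 3 (0.40 log units; beyond the scatter): with 4-fluorophenyl in place of 3,4-dichlorophenyl on the oxygen, growth inhibition weakens by a modest amount. Compound 3 still gives an actual number in this assay, 79400 nM, and not a limit, so the swap leaves this position readable on the scale of the assay. Nothing among the data shown accounts for the size of this step.

The swap removes both chlorines and brings in fluorine in one move, so the compounds shown cannot separate what each of these contributes. From the compounds shown here alone, it also stays open whether a 4-chlorophenyl, an unsubstituted phenyl, or a phenyl carrying an amine or a carboxylic acid on this oxygen would move the number further, and in which direction.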